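Compound 3 and a Stereocentre Drawn Without Configuration

A few compounds are considered here, and "the series" means these few. Any claim that something is new, unique, unknown or untested is made for them only; others in the source may bear on it.

In a physicochemical assay for solubility, read by chemiluminescence, measured as kinetic solubility (on this read-out higher numbers stand for higher solubility and lower numbers for lower solubility), compound 1 `O=C(C1CCCNC1)N1CCC2(CCN(c3nccc(NCc4ccc(Cl)cc4Cl)n3)CC2)C1` gives 186 ug/mL. Compound 2 `O=C(c1ccccn1)N1CCC2(CCN(c3nccc(NCc4ccc(Cl)cc4Cl)n3)CC2)C1` gives 17 ug/mL, and compound 3 `Clc1ccc(CNc2ccnc(N3CCC4(CCN(C[C@H]5CCCN5)C4)CC3)n2)c(Cl)c1` gives 16 ug/mL. Compound 3 thus shares the low end of these numbers with compound 2: there is a 1.1-fold lower number from compound 2 to compound 3 (0.03 log units; within the scatter), against a 12-fold lower number from compound 1 to compound 3 (1.07 log units; beyond the scatter).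

Compound 4 `Clc1ccc(CNc2ccnc(N3CCC4(CCN(CC5CCCN5)C4)CC3)n2)c(Cl)c1` has the same atoms and bonds as compound 3: the two compounds have the same atoms and bonds; at least one stereo element is drawn with a configuration in one of them and without one in the other: 1 of 1 stereo elements differ; a stereocentre at a saturated ring carbon is drawn R in compound 3 and without a configuration in compound 4, a stereocentre at a saturated ring carbon drawn R in compound 3 and without a configuration in compound 4.

The measured steps give no direct guide to such a change. The large ones, such as an 11-fold lower number from compound 1 to compound 2 (1.04 log units; beyond the scatter), exchange a whole group, as do the other two steps, and none alters only a configuration. The expectation therefore starts from compound 3 at 16 ug/mL, with no step beyond the scatter expected in this assay. The step expected is a 1.1-fold higher number from compound 3 to compound 4 (0.03 log units; within the scatter). For compound 4 the estimate is 17 ug/mL, with an expected range of 8 ug/mL to 35 ug/mL.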

Compound 4, solubility: 270 ug/mL
The estimate for compound 4 lay 16-fold (1.20 log units) below the measured number; measured number above the stated range.
By their numbers in this assay, from the lowest: compounds 3 and 2 (each within the scatter of the next); then compounds 1 and 4 (each within the scatter of the next).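

In this assay, among the compounds shown here, the stereocentre at a saturated ring carbon gives a 17-fold higher number from compound 3 to compound 4 (1.23 log units; beyond the scatter), a large step with no atom or bond changed, whereas the earlier compounds showed large steps only when a whole group was exchanged. The (pyrrolidin-2-yl)methyl group therefore does not by itself tie a compound to the low end of the read-out: in place of (pyridin-2-yl)carbonyl it gives a 16-fold higher number from compound 2 to compound 4 (1.20 log units; beyond the scatter), and in place of (piperidin-3-yl)carbonyl it gives a 1.5-fold higher number from compound 1 to compound 4 (0.16 log units; within the scatter). All that separates the two structures as drawn is this: the fact that one of compounds 3 and 4 is drawn with a defined configuration and the other without, at the place where they differ.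

The compounds shown leave open what compound 4 actually holds at that carbon, whether a single configuration or a mixture, and so whether the step belongs to the configuration at all. They also leave open how a form drawn S would read, and whether a piperidine in place of the pyrrolidine would show the same gap.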